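A Triazole Aryl Swap on an Ester at the Limit

The source may report more compounds than this note shows. Statements on the series, on what has been measured and on what is new or still open speak of the compounds shown alone.

Compound 1 `C#CCOC(=O)/C(C)=C/CC/C(C)=C/CC/C(C)=C/CC[C@@H]1[C@@]2(C)CCC(=O)C(C)(C)[C@H]2CC[C@@]1(C)O`: 45100 nM
Compound 2 `C/C(=C\CC/C(C)=C/CC[C@@H]1[C@@]2(C)CCC(=O)C(C)(C)[C@H]2CC[C@@]1(C)O)CC/C=C(\C)C(=O)OCc1cn(-c2ccccc2C)nn1`: > 150000 nM
Compound 3 `C/C(=C\CC/C(C)=C/CC[C@@H]1[C@@]2(C)CCC(=O)C(C)(C)[C@H]2CC[C@@]1(C)O)CC/C=C(\C)C(=O)O`: > 150000 nM

In a functional assay on A549 cells (Homo sapiens) for antiproliferative activity, read by MTT assay, with a stated time of 48 h (a lower number here means a stronger inhibitor, a higher number a weaker inhibitor), compound 1 gives 45100 nM. For compound 2 the value > 150000 nM is a limit of the assay, not a number. Compound 3 also sits at a limit, > 150000 nM. Compound 2 thus stands at the limit of > 150000 nM in this assay, at which 2 of the 3 values shown sit, with no measured number of its own. Compound 4 `C/C(=C\CC/C(C)=C/CC[C@@H]1[C@@]2(C)CCC(=O)C(C)(C)[C@H]2CC[C@@]1(C)O)CC/C=C(\C)C(=O)OCc1cn(-c2cccc(C(F)(F)F)c2)nn1` carries 3-(trifluoromethyl)phenyl in place of 2-methylphenyl on an aromatic nitrogen. Among the measured compounds shown here, only two measured steps are known, an at least 3.3-fold higher number from compound 1 to compound 2 (0.52 log units; beyond the scatter) and an at least 3.3-fold higher number from compound 1 to compound 3 (0.52 log units; beyond the scatter), and both alter the ester end rather than the ring that is swapped here, so neither bears directly on this change. No step beyond the scatter is therefore expected in this assay. Compound 4 is expected to remain at or near the limit, estimated at 150000 nM (60000 nM to 400000 nM). This expectation amounts to a step of a number no higher from compound 2 to compound 4 (the limit leaves the size open).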

Compound 4, half-maximal inhibitory concentration: > 150000 nM
Compound 4: no number, only a limit; the forecaster's own chance of this, stated with the estimate: 70%; the middle value sits exactly at the limit.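

Compound 2 and compound 4 both give only a limit in this assay, not a number, so no step between them can be read: the limit of > 150000 nM in this assay, at which 3 of the 4 values shown sit.

On these data alone, whether 3-(trifluoromethyl)phenyl and 2-methylphenyl differ in activity stays open.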